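This account rests on a few compounds, and the source may have more. Where it says the series, first, only, none or still open, it means among the compounds named here.

Compound 2 `COc1cc2cc(Oc3ccc(NC(=O)Nc4ccc(Cl)c(C(F)(F)F)c4)cc3)c(C)nc2cc1OC` shares its core with compound 1 `COc1cc2cc(Oc3ccc(NC(=O)Nc4cccc(C(F)(F)F)c4)cc3)c(C)nc2cc1OC`; the two differ only in a chloro in place of hydrogen on an aromatic carbon of the urea-bearing ring. In a functional assay on UACC-257 cells (Homo sapiens) for inhibition, read by sulforhodamine B assay, with a stated time of 48 h (a higher number here means a weaker inhibitor of growth, a lower number a stronger inhibitor of growth), compound 1 gives 1090 nM, and compound 2 gives 710 nM, so that a 1.5-fold lower number from compound 1 to compound 2 (0.19 log units; within the scatter). On these two numbers compound 2 carries the lower figure, though the step that separates it from compound 1 does not exceed the scatter, and no order between them can be read.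

Compound 3 `COc1cc2cc(Oc3ccc(NC(=O)Nc4ccc(Cl)c(Cl)c4)cc3)c(C)nc2cc1OC` keeps the chloro that compound 2 gained and alters the neighbouring substituent: chloro in place of trifluoromethyl on an aromatic carbon. Among the measured compounds shown here, none of the measured steps replaces a trifluoromethyl by a chloro; the one measured step, from compound 1 to compound 2, concerns a different position and was itself within the scatter. With nothing in the data pointing either way, the expectation for compound 3 in this assay is a step of about a 1.3-fold higher number from compound 2 to compound 3 (0.10 log units; within the scatter), that is no step beyond the scatter. Compound 3 is therefore estimated at 900 nM, with a range from 350 nM to 2500 nM.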

Compound 3, concentration for 50% growth inhibition: 2310 nM
Compound 3: middle estimate off by 2.6-fold (0.41 log units), on the low side, within the range that was stated.
By their numbers in this assay, from the lowest: compounds 2 and 1 (each within the scatter of the next); then compound 3.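

In this assay, among the compounds shown here, the change from trifluoromethyl to chloro on this aromatic carbon, ortho to a chloro group, is the first step to pass the scatter (a 3.3-fold higher number from compound 2 to compound 3 (0.51 log units; beyond the scatter)). The same direction appears against compound 1 (a 2.1-fold higher number from compound 1 to compound 3 (0.33 log units; beyond the scatter)), so the 3,4-dichlorophenyl urea stands apart from both trifluoromethyl-bearing compounds, whereas the earlier chloro-for-hydrogen step between those two stayed within the scatter and gave no order. At this position, then, the identity of the group shows in the read-out, and trifluoromethyl goes with the lower numbers in these three compounds, although nothing available offers a measured reason for the step.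

On these data alone, what a methoxy, a nitrile, a bromo or an amine would give on this same carbon remains open, so two groups alone cannot show whether trifluoromethyl is a special case or one end of a wider range. Also open, as far as these compounds go, is whether the step keeps its size and direction on the 3-(trifluoromethyl)phenyl ring without its chloro, or with a longer chain in place of the methyl on the shared core.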